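Benzylidene-amino analogue of a paw-edema series

The source may report more compounds than this note shows. Statements on the series, on what has been measured and on what is new or still open speak of the compounds shown alone.

Measured compounds:
compound 1 `N#CC1=C(NCC(=O)N2CCOCC2)N(c2ccccc2)C(=O)N2CCCCC(N3CCCC3)C12` — 43.9%
compound 2 `COc1ccc(N/C=N/C2=C(C#N)C3C(N4CCCC4)CCCCN3C(=O)N2c2ccccc2)cc1` — 20.6%

In a functional assay on the whole organism (strain albino) for inhibition, with Rattus norvegicus as the target, read by paw edema, with a stated time of 1 h, at a dose of 20 mmol/kg by the intraperitoneal route (on this read-out lower numbers stand for less inhibition and higher numbers for more inhibition at the one dose given (going by the name of the read-out)), compound 1 gives 43.9% and compound 2 gives 20.6%, so compound 2 stands lowest of the two. Going by the values given here, the only measured step, a number 23.3 percentage points lower from compound 1 to compound 2 (beyond the scatter), concerns a different part of the molecule from the change now in question. Compound 3 `N#CC1=C(/N=C/c2ccccc2)N(c2ccccc2)C(=O)N2CCCCC(N3CCCC3)C12` differs from compound 2 by phenyl in place of (4-methoxyphenyl)amino on a carbon with a double bond to nitrogen. Among the compounds with values here, no measured step bears on this exchange, so there is no basis for expecting a step beyond the scatter in either direction in this assay. The estimate for compound 3 therefore rests on the number of compound 2 alone, and compound 3 is expected to give 24% (range 8% to 42%). The estimated step of a number 3.4 percentage points higher from compound 2 to compound 3 (within the scatter) is expected to lie within the scatter.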

Compound 3, a percentage reported as inhibition, in the whole organism at one dose (the size of the read-out at that dose, not a potency): 46.5%
Compound 3: middle estimate off by 22.5 percentage points, on the low side, outside the stated range (above it).
By their numbers in this assay, from the lowest: compound 2; then compounds 1 and 3 (each within the scatter of the next).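

In this assay, the exchange of (4-methoxyphenyl)amino for phenyl on a carbon with a double bond to nitrogen comes with a number 25.9 percentage points higher from compound 2 to compound 3 (beyond the scatter), so the read-out is sensitive to the group held at this place. Going by these compounds alone, the comparison on the double-bonded ring carbon, a number 2.6 percentage points higher from compound 1 to compound 3 (within the scatter), does not separate the group carried there by compound 1 from the one carried by compound 3, although the earlier step had set compound 1 clearly apart from compound 2. Nothing at hand bears on what lies behind these steps.

The compounds shown do not tell whether the step follows the amino link or the methoxy group of the group that leaves. A plain phenylamino group or a 4-methoxyphenyl group on the same carbon would separate the two.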